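This account rests on a few compounds, and the source may have more. Where it says the series, first, only, none or still open, it means among the compounds named here.

Measured so far in an ADME assay on BJ cells (Homo sapiens) for cytotoxicity, with a stated time of 72 h; on this read-out higher numbers stand for an effect only at larger amounts of compound and lower numbers for an effect already at smaller amounts:
compound 1 `Cc1cc(NC(=O)c2cc([N+](=O)[O-])ccc2Cl)cc(-c2nc3ccccc3o2)c1O` – > 25000 nM, a limit of the assay
compound 2 `Cc1cc(NC(=O)c2cc([N+](=O)[O-])ccc2Cl)cc(-c2nc3ccccc3s2)c1O` – > 25000 nM, a limit of the assay
compound 3 `Cc1ccc(-c2nc3ccccc3s2)cc1NC(=O)c1cc([N+](=O)[O-])ccc1Cl` – > 14000 nM, a limit of the assay

Compounds 1 and 2 share one core; compound 3 is built on a different core, and the difference between the two cores is not broken down here. From compound 2 to compound 1 the change is 1,3-benzoxazol-2-yl in place of 1,3-benzothiazol-2-yl on an aromatic carbon. The step that the two limits leave unreadable from compound 2 to compound 1 cannot be read in size because both values sit at the limit of > 25000 nM in this assay, at which 2 of the 3 values shown sit.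

Compound 4 `Cc1ccc(-c2nc3ccccc3o2)cc1NC(=O)c1cc([N+](=O)[O-])ccc1Cl` has not yet been measured. It differs from compound 3 by 1,3-benzoxazol-2-yl in place of 1,3-benzothiazol-2-yl on an aromatic carbon. This is the same kind of change as from compound 2 to compound 1, but the surroundings differ: in compound 2 the site is ortho to a hydroxy group and meta to a methyl group, whereas in compound 3 it is para to a methyl group.

Among the measured compounds shown here, no compound in this set has yet given a number in this assay. Compound 3 sits at the limit of > 14000 nM in this assay, at which 1 of the 3 values shown sits, and the earlier change of the same kind left no readable step. On that basis the step from compound 3 to compound 4 is expected to be small, a step that the limit leaves unreadable from compound 3 to compound 4. For compound 4 the estimate in this assay is 25000 nM, within 10000 nM to 60000 nM, and most probably the assay will again report only a limit for compound 4.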

Compound 4, half-maximal effective concentration: > 14000 nM
Compound 4: a limit, no number (the forecaster's own chance of this, stated with the estimate: 85%); the middle value does not contradict the limit.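

In this assay compound 3 and compound 4 both give only a limit, and no size can be read for the change between them because of where they sit: the limit of > 14000 nM in this assay, at which 2 of the 4 values shown sit.

Compounds 1, 2, 3 and 4 all stand at limits, which leaves open whether 1,3-benzoxazol-2-yl in place of 1,3-benzothiazol-2-yl changes the read-out at all, on either core.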